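The compounds below may be only part of what the source reports. "The series", "measured", "known", "first", "only" and "open" are said of these compounds alone.

Of the compounds shown here, three have been measured in a functional assay on HL-60 cells (Homo sapiens) for cytotoxicity, read by luminescence and CellTiter-Glo, with a stated time of 3 days; on this read-out higher numbers stand for weaker inhibition and lower numbers for stronger inhibition. Compound 1 `N#Cc1ccc(NC(=O)c2ccc(-c3cccnc3)cc2O)cc1` gives 6660 nM, the highest of the three numbers. Compound 2 `O=C(Nc1ccc(C(F)(F)F)cc1)c1cc(Br)ccc1O` gives 580 nM, and compound 3 `O=C(Nc1ccc(C(F)(F)F)c(Cl)c1)c1cc(Cl)ccc1O` gives 460 nM; both stand beyond the scatter from compound 1, on the side of stronger inhibition. Compound 4 `N#Cc1ccc(NC(=O)c2ccccc2O)cc1` has not yet been measured. It differs from compound 1 by hydrogen in place of pyridin-3-yl on an aromatic carbon, so the pyridin-3-yl is removed and only a hydrogen remains at that spot. Going by the values given here, no measured pair shows this kind of change, so the size of its effect is open. A small shift toward weaker inhibition of about a 1.7-fold higher number from compound 1 to compound 4 (0.22 log units; within the scatter) is expected. Compound 4 is expected to give about 11000 nM in this assay, within a range of 4000 nM to 30000 nM.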

Compound 4, half-maximal inhibitory concentration: 4620 nM
For compound 4 the middle estimate is 2.4-fold (0.38 log units) above the measured one; measured number inside the range.
By their numbers in this assay, from the lowest: compounds 3 and 2 (each within the scatter of the next); then compounds 4 and 1 (each within the scatter of the next).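

In this assay, putting hydrogen in place of the pyridin-3-yl gives a 1.4-fold lower number from compound 1 to compound 4 (0.16 log units; within the scatter) and so stays within the usual scatter. An entire six-membered aromatic ring can therefore leave this spot, meta to a hydroxy group, without a shift that can be told apart from repeat-to-repeat variation. Nothing at hand accounts for this outcome. Still open, as far as these compounds go, is whether a small group at this spot, such as an amine or a carboxylic acid, would behave the same way. Also open, from the compounds shown here alone, is whether any group here can move the number beyond the scatter.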